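Acetyl for tert-butyl in a sulfamoyl carbamate series

The source may report more compounds than this note shows. Statements on the series, on what has been measured and on what is new or still open speak of the compounds shown alone.

Of the compounds shown here, two have been tested in an assay on liver for inhibition of sterol O-acyltransferase 1 (Rattus norvegicus), using microsomes; on this read-out higher numbers stand for weaker inhibition and lower numbers for stronger inhibition. Compound 1, `CCC(C)N(C(=O)NS(=O)(=O)Oc1c(C(C)C)cccc1C(C)C)C(C)CC`, gives 12000 nM. Compound 2, `CC(C)c1cc(C(C)(C)C)cc(C(C)C)c1OC(=O)NS(=O)(=O)Oc1c(C(C)C)cccc1C(C)C`, carries a tert-butyl group on its phenyl carbamate and gives 8800 nM; this is the lower of the two numbers, yet it lies within the scatter of compound 1, so the two cannot be told apart on these data.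

Compound 3, `CC(=O)c1cc(C(C)C)c(OC(=O)NS(=O)(=O)Oc2c(C(C)C)cccc2C(C)C)c(C(C)C)c1`, is still to be measured. It differs from compound 2 in one place: acetyl in place of tert-butyl on an aromatic carbon, on a carbon that is meta to two isopropyl groups and para to a large group.

Within the data shown here, no measured pair shows what such a swap does in this assay, so nothing more than the scatter can be claimed either way. The estimate for compound 3 in this assay is therefore close to compound 2, at 10000 nM with a range from 3000 nM to 30000 nM. That expected outcome corresponds to a step of a 1.1-fold higher number from compound 2 to compound 3 (0.06 log units; within the scatter).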

Compound 3, half-maximal inhibitory concentration: 41800 nM
Beside the measured number, compound 3's estimate is 4.2-fold (0.62 log units) below it; the measured number lies above the stated range.
By their numbers in this assay, from the lowest: compounds 2 and 1 (each within the scatter of the next); then compound 3.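

In this assay, among these compounds, the swap of tert-butyl for acetyl on this aromatic carbon, which is meta to two isopropyl groups and para to a large group, gives a 4.8-fold higher number from compound 2 to compound 3 (0.68 log units; beyond the scatter) and is the first change in this set to go beyond the usual scatter of repeated measurements. Inhibition is therefore weaker with acetyl, so what this carbon carries does affect the read-out, at least for this pair. The change replaces a group of 4 carbon atoms with one that has 3 heavy atoms, a double bond and 1 hydrogen-bond acceptor, but no measurement here explains the loss.

This single pair cannot separate losing tert-butyl from gaining acetyl. It also leaves open what an amine, a carboxylic acid or a longer chain on this carbon would do.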